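Methyl to Trifluoromethyl: A Small Step Repeated

The source may hold more compounds than are shown below. What is called first, only, known or untested is meant among the compounds shown, and "the series" means these compounds.

Of the compounds shown here, three that share one core have been measured in a functional assay on KB cells (Homo sapiens) for antiproliferative activity, read by sulforhodamine B assay, with a stated time of 3 days; a lower number here means that less compound is needed, a higher number that more compound is needed for the effect. Compound 1 `CCC1=C(O)c2c(oc(-c3ccc(C)cc3)cc2=O)C(CC)(CC)C1=O` gives 39.2 uM. Compound 2 `CCC1=C(O)c2c(oc(-c3ccc(C(F)(F)F)cc3)cc2=O)C(CC)(CC)C1=O` gives 35.7 uM, and compound 3 `CCC1=C(O)c2c(oc(-c3ccccc3C)cc2=O)C(CC)(CC)C1=O` gives 40.9 uM. All three numbers lie close together.

Compound 2 differs from compound 1 in one place: trifluoromethyl in place of methyl on an aromatic carbon. That change made a 1.1-fold lower number from compound 1 to compound 2 (0.04 log units; within the scatter). Compound 3 differs from compound 1 only in how the same atoms are joined: 2-methylphenyl in place of 4-methylphenyl on an aromatic carbon. This rearrangement made a 1.0-fold higher number from compound 1 to compound 3 (0.02 log units; within the scatter).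

Compound 4 `CCC1=C(O)c2c(oc(-c3ccccc3C(F)(F)F)cc2=O)C(CC)(CC)C1=O` has not yet been measured. It stands to compound 3 as compound 2 stands to compound 1: trifluoromethyl in place of methyl on an aromatic carbon. The surroundings are not identical, though. In compound 2 the entering group sits para to a large group, whereas in compound 4 it sits ortho to a large group, so this counts as the same kind of change rather than the same change.

Among the measured compounds shown here, the one earlier example of this kind of change stayed within the scatter, and compound 3 itself sits within the scatter of compound 1, so little movement is expected here either. The step from compound 3 to compound 4 is expected to be a 1.1-fold lower number from compound 3 to compound 4 (0.03 log units; within the scatter). Compound 4 is accordingly estimated at 38 uM in this assay, with a range from 20 uM to 72 uM expected to cover most repeat measurements. This expectation rests on a single prior instance among three compounds, and the measurement itself will show whether the ortho setting behaves differently.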

Compound 4, concentration for half-maximal effect: 45.6 uM
The estimate for compound 4 lay 1.2-fold (0.08 log units) below the measured number; the range from low to high includes it.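

Putting trifluoromethyl in place of methyl on the ring of compound 3, where it sits ortho to a large group, gave a 1.1-fold higher number from compound 3 to compound 4 (0.05 log units; within the scatter) in this assay. Set beside the earlier example, the same swap shows no detectable difference between the two cores: the same change on two cores in this assay, a 1.1-fold lower number (0.04 log units; within the scatter) from compound 1 to compound 2 and a 1.1-fold higher number (0.05 log units; within the scatter) from compound 3 to compound 4, 1.2-fold (0.09 log units) apart, within the scatter of two such steps. Among the compounds shown here, this shows only that the swap left the number within the scatter in both pairs; it does not show that the swap has no effect at all, since a small real effect could hide inside the scatter, and two steps this small are a weak test of whether a change carries from one core to another, so they give no rule for other cores or other assays.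

Going by these compounds, all four compounds carry either methyl or trifluoromethyl on that aromatic ring, so it remains open whether an amine, a carboxylic acid or a longer chain in the same place would move the number beyond the scatter. The ethyl groups on the shared core are also the same throughout, which leaves open what a shorter or longer chain there would do.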